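A few compounds are considered here, and "the series" means these few. Any claim that something is new, unique, unknown or untested is made for them only; others in the source may bear on it.

Among the compounds with values here, in an ADME assay on SH-SY5Y cells (Homo sapiens) for cytotoxicity, read by MTT assay, with a stated time of 72 h (on this read-out lower numbers stand for stronger inhibition and higher numbers for weaker inhibition), three compounds with a shared core have numbers so far: compound 1 `COc1ccc(C(=O)N2CCN(CC(=O)N3CCN(CCCc4c[nH]c5ccccc45)CC3)CC2)cc1` gives 148000 nM, compound 2 `O=C(CN1CCN(C(=O)c2ccc(F)cc2)CC1)N1CCN(CCCc2c[nH]c3ccccc23)CC1` gives 188000 nM, and compound 3 `O=C(CN1CCN(C(=O)c2cccc(Cl)c2)CC1)N1CCN(CCCc2c[nH]c3ccccc23)CC1` gives 120000 nM. Compound 3 does not stand apart from the other two. The data show a 1.2-fold lower number from compound 1 to compound 3 (0.09 log units; within the scatter) and a 1.6-fold lower number from compound 2 to compound 3 (0.19 log units; within the scatter), so its number cannot be separated from either neighbour.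

The next compound to be tested is compound 4 `COc1cccc(C(=O)N2CCN(CC(=O)N3CCN(CCCc4c[nH]c5ccccc45)CC3)CC2)c1`, and the change from compound 3 is methoxy in place of chloro on an aromatic carbon, meta to a large group. The nearest evidence comes from the aryl changes already measured. Compound 1 also carries a methoxy, as 4-methoxyphenyl, and exchanging that group for 3-chlorophenyl gave only the small step to compound 3 noted above. Replacing the methoxy with fluoro gave a 1.3-fold higher number from compound 1 to compound 2 (0.10 log units; within the scatter), also within the scatter. None of the three measured changes on this aryl group moved the number beyond the scatter, so no step beyond the scatter is expected here in either direction.

The expected change is a 1.2-fold higher number from compound 3 to compound 4 (0.08 log units; within the scatter), an estimate that stays within the scatter. For compound 4 the estimated value is 145000 nM, with an expected range from 85000 nM to 240000 nM.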

Compound 4, half-maximal inhibitory concentration: > 200000 nM
Compound 4 gave a limit, no number; the forecaster's own chance of this, stated with the estimate: 8%; middle value at least 1.3-fold (0.13 log units) away from the limit.
By their numbers in this assay, from the lowest: compounds 3, 1 and 2 (each within the scatter of the next). At a limit, above all of these: compound 4.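

In this assay, compound 4 gives a limit and not a number: the limit of > 200000 nM in this assay, at which 1 of the 4 values shown sits. At this position, on an aromatic carbon meta to a large group, methoxy in place of chloro gives an at least 1.6-fold higher number from compound 3 to compound 4 (0.22 log units; that floor lies within the scatter), and the same read-out holds for 3-methoxyphenyl in place of 4-methoxyphenyl, with an at least 1.3-fold higher number from compound 1 to compound 4 (0.13 log units; that floor lies within the scatter), and in place of 4-fluorophenyl, with an at least 1.0-fold higher number from compound 2 to compound 4 (0.02 log units; that floor lies within the scatter). Within the data shown here, each of these is a floor within the scatter, so the result does not prove a real separation, but it is the first aryl change with no upper bound on its size, which the steps among the earlier three compounds, all exact and all within the scatter, could not show.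

From the compounds shown here alone, how far compound 4 truly lies from the other three stays open, since its limit leaves room for anything from no real difference to a large one. Also open, going by these compounds, is whether an amine, a carboxylic acid or a longer alkoxy chain in place of the methoxy on this ring would give a number or another limit.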